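The source may hold more compounds than are shown below. What is called first, only, known or untested is meant among the compounds shown, and "the series" means these compounds.

Compound 3 `c1ccc(Cn2cnc3c(-c4ccco4)ncnc32)cc1` stands at the highest number shown in a functional assay on K562 cells (Homo sapiens), read by thymidine incorporation (on this read-out higher numbers stand for weaker inhibition and lower numbers for stronger inhibition), 59 ug/mL. Compound 2 `C=CCn1cnc2c(-c3ccco3)ncnc21` gives 11 ug/mL. Compound 1 `Cn1cnc2c(-c3ccco3)ncnc21` sits at a limit of the assay, < 10 ug/mL. Among the compounds with values here, the step of a 5.4-fold higher number from compound 2 to compound 3 (0.73 log units; beyond the scatter) is the one firm number of the three; an at least 5.9-fold higher number from compound 1 to compound 3 (0.77 log units; beyond the scatter) rests on the limit (the limit of < 10 ug/mL in this assay, at which 1 of the 3 values shown sits), and an at least 1.1-fold higher number from compound 1 to compound 2 (0.04 log units; that floor lies within the scatter) lies within the scatter. Compound 4 `c1coc(-c2ncnc3c2ncn3CC2CCCCC2)c1` differs from compound 3 by cyclohexyl in place of phenyl on a saturated chain carbon bound to an aromatic nitrogen. Only the vinyl-to-phenyl step bears on this, and it shows phenyl carrying the highest number; a saturated ring in this place has not yet been measured. The expectation for compound 4 is a step of a 2.0-fold lower number from compound 3 to compound 4 (0.29 log units; within the scatter), toward a lower number but smaller than the measured phenyl step. Compound 4 is estimated at 30 ug/mL, with a range from 10 ug/mL to 90 ug/mL.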

Compound 4, half-maximal inhibitory concentration: 60 ug/mL
For compound 4 the middle estimate is 2.0-fold (0.30 log units) below the measured one, within the range that was stated.
By their numbers in this assay, from the lowest: compound 2; then compounds 3 and 4 (each within the scatter of the next). At a limit, below all of these: compound 1.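

Replacing the aromatic ring with a saturated one at this position leaves no readable change in this assay: a 1.0-fold higher number from compound 3 to compound 4 (0.01 log units; within the scatter). The cyclohexyl compound stands as far from the vinyl compound as the phenyl compound does, so for these two rings, aromatic or not makes no readable difference: a 5.5-fold higher number from compound 2 to compound 4 (0.74 log units; beyond the scatter). The step of an at least 6.0-fold higher number from compound 1 to compound 4 (0.77 log units; beyond the scatter) rests on the limit of compound 1 and gives only a floor: the limit of < 10 ug/mL in this assay, at which 1 of the 4 values shown sits.

Still open, on these data alone, is how a longer chain such as butyl would read on this carbon. Also open, as far as these compounds go, is how a phenyl ring carrying an amine or a carboxylic acid would read there.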